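Bromo in place of chloro on the 4-chlorophenyl group

The compounds below may be only part of what the source reports. "The series", "measured", "known", "first", "only" and "open" are said of these compounds alone.

In a functional assay on HL-60 cells (Homo sapiens) for cytotoxicity, read by MTT assay, with a stated time of 46 h (a lower number here means a stronger inhibitor, a higher number a weaker inhibitor), compound 1 (`O=C1/C(=C/c2ccncc2)C(c2ccccc2)Oc2ccccc21`) gives 900 nM, compound 2 (`Cc1ccc(/C=C2/C(=O)c3ccccc3OC2c2ccccc2)cc1`) gives 40900 nM and compound 3 (`O=C1/C(=C/c2ccc(Cl)cc2)C(c2ccccc2)Oc2ccccc21`) gives 5800 nM. Compound 3 therefore stands in the middle of the three numbers, with compound 1 lower and compound 2 higher. Replacing pyridin-4-yl with 4-methylphenyl gave a 45-fold higher number from compound 1 to compound 2 (1.66 log units; beyond the scatter), and replacing it with 4-chlorophenyl gave a 6.4-fold higher number from compound 1 to compound 3 (0.81 log units; beyond the scatter). Compound 4 (`O=C1/C(=C/c2ccc(Br)cc2)C(c2ccccc2)Oc2ccccc21`) carries bromo in place of chloro on an aromatic carbon, para to a large group: bromo in place of chloro on an aromatic carbon. The closest measured change is chloro in place of methyl on that aromatic carbon, which gave a 7.1-fold lower number from compound 2 to compound 3 (0.85 log units; beyond the scatter), so a change at this carbon can move the number beyond the scatter. No measured step exchanges one halogen for another, however, and the range stays wide for that reason. The estimate amounts to an expected 1.0-fold higher number from compound 3 to compound 4 (0.01 log units; within the scatter), with no shift beyond the scatter expected in either direction. Starting from the 5800 nM of compound 3, compound 4 is expected at 6000 nM, with an estimated range from 2500 nM to 15000 nM.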

Compound 4, half-maximal inhibitory concentration: 5700 nM
Compound 4: the middle estimate sits 1.1-fold (0.02 log units) above what was measured; the measured number falls inside the stated range.
By their numbers in this assay, from the lowest: compound 1; then compounds 4 and 3 (each within the scatter of the next); then compound 2.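

In this assay, the exchange of chloro for bromo on this aromatic carbon, para to a large group, separates compound 3 and compound 4 by no more than the usual scatter (a 1.0-fold lower number from compound 3 to compound 4 (0.01 log units; within the scatter)), and this is the first halogen-for-halogen step among the compounds shown. The bromo compound sits much where the chloro compound sat relative to the other two, with a 7.2-fold lower number from compound 2 to compound 4 (0.86 log units; beyond the scatter) when bromo replaces methyl and a 6.3-fold higher number from compound 1 to compound 4 (0.80 log units; beyond the scatter) when 4-bromophenyl replaces pyridin-4-yl. No independent measurement bears on this result.

The compounds shown leave open whether fluoro or iodo on this carbon would also stay level with chloro and bromo. They also leave open how a methoxy group or an amine there would compare, and whether pyridin-3-yl would match pyridin-4-yl.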